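Replacing trifluoromethyl with hydrogen on compound 2

The source may report more compounds than this note shows. Statements on the series, on what has been measured and on what is new or still open speak of the compounds shown alone.

In a functional assay on MCF7 cells (Homo sapiens) for cytotoxicity, read by MTT assay, with a stated time of 24 h (on this read-out higher numbers stand for weaker inhibition and lower numbers for stronger inhibition), compound 1 (`O=C(Nc1ccccc1)Nc1cccc2c(O)cccc12`) gives 953 nM. Compound 2 (`CC(=O)Nc1ccc(Oc2cccc3c(NC(=O)Nc4cccc(C(F)(F)F)c4)cccc23)cc1`) gives 953 nM, which places it level with compound 1. Compound 3 (`CC(=O)Nc1ccc(Oc2cccc3c(NC(=O)Nc4ccccc4)cccc23)cc1`) has not yet been measured. It has hydrogen in place of trifluoromethyl on an aromatic carbon of compound 2 (hydrogen in place of trifluoromethyl on an aromatic carbon). Among the compounds with values here, no measured pair shows this change directly, which leaves the expectation uncertain. Compound 1 also carries no trifluoromethyl and gives 953 nM, so no step beyond the scatter is expected in this assay. Compound 3 is expected at 1100 nM, with an estimated range from 300 nM to 4000 nM.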

Compound 3, half-maximal inhibitory concentration: 953 nM
For compound 3 the middle estimate is 1.2-fold (0.06 log units) above the measured one; the range from low to high includes it.
By their numbers in this assay, from the lowest: compounds 1, 2 and 3 (each within the scatter of the next).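

In this assay, taking trifluoromethyl off the aromatic ring gives no change at the digits printed from compound 2 to compound 3 (within the scatter), so on this read-out the position accepts hydrogen as well as trifluoromethyl. Putting 4-acetamidophenyl in place of hydrogen on the oxygen gives no change at the digits printed from compound 1 to compound 3 (within the scatter), so that much larger change also leaves the read-out level. Nothing available explains why these values stay level.

As far as these compounds go, whether an amine or a carboxylic acid at the trifluoromethyl position would move the value remains open. So does whether a longer chain on the oxygen would.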